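Chloro for hydrogen on the shared core: cytotoxicity notes

The source may hold more compounds than are shown below. What is called first, only, known or untested is meant among the compounds shown, and "the series" means these compounds.

Compound 1 `ClCc1ccccc1Cn1cnc2c(Cl)nc(Cl)nc21` and compound 2 `ClCc1ccccc1Cn1cnc2c(Cl)ncnc21` share a core and differ in one place. In a functional assay on NCI-H460 cells (Homo sapiens) for cytotoxicity, read by sulforhodamine B assay, with a stated time of 48 h (a lower number here means that less compound is tolerated, a higher number that more compound is tolerated), compound 1 gives only a limit, > 100000 nM. In this assay compound 2 likewise gives a limit, > 100000 nM. Compound 1 differs from compound 2 by chloro in place of hydrogen on an aromatic carbon. This amounts to a step that the two limits leave unreadable from compound 2 to compound 1. Compound 3 `ClCc1cccc(Cn2cnc3c(Cl)ncnc32)c1` has the same atoms as compound 2, joined differently; the difference between the two cores is not broken down here. In this assay compound 3 gives a limit, > 100000 nM. Compound 4 `ClCc1cccc(Cn2cnc3c(Cl)nc(Cl)nc32)c1` is not yet measured and differs from compound 3 by chloro in place of hydrogen on an aromatic carbon, the same change at a place described in the same words. Because all three values sit at the limit of > 100000 nM in this assay, at which 3 of the 3 values shown sit, the size of this change cannot be read. The step from compound 3 to compound 4 is expected to be a step that the limit leaves unreadable from compound 3 to compound 4. Compound 4 is estimated at 150000 nM, most probably again only a limit.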

Compound 4, concentration lethal to 50% of the cells: > 100000 nM
Compound 4: a limit, no number; the forecaster's own chance of this, stated with the estimate: 85%; the middle value does not contradict the limit.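

No step can be read from compound 3 to compound 4 in this assay as both give only a limit: the limit of > 100000 nM in this assay, at which 4 of the 4 values shown sit.

As far as these compounds go, whether chloro in place of hydrogen changes the result in this assay at all stays open.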